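The compounds below may be only part of what the source reports. "The series", "measured", "known", "first", "only" and "open" are said of these compounds alone.

Measured in a functional assay on A549 cells (Homo sapiens) for antiproliferative activity, read by MTT assay, with a stated time of 48 h; a higher number here means a weaker inhibitor, a lower number a stronger inhibitor:
- compound 1 `CCCCCC1(O)C(=O)Nc2ccc(Nc3ccc(OC)cc3)cc21`: 8000 nM
- compound 2 `COc1ccc(Nc2ccc3c(c2)C(O)(Cc2ccccc2)C(=O)N3)cc1`: > 30000 nM (a limit, not a number)

Compound 2 stands at the limit of > 30000 nM in this assay, at which 1 of the 2 values shown sits, so it has a limit only. Compound 3 `O=C1Nc2ccc(Nc3ccc(F)cc3)cc2C1(O)Cc1ccccc1` differs from it by fluoro in place of methoxy on an aromatic carbon, para to a large group: fluoro in place of methoxy on an aromatic carbon. Within the data shown here, the only measured step, an at least 3.7-fold higher number from compound 1 to compound 2 (0.57 log units; beyond the scatter), is phenyl in place of butyl on a saturated chain carbon, elsewhere in the molecule, so it does not size this change. Among the measured compounds shown here, no measured step bears on the swap itself. Compound 3 keeps the phenyl of compound 2, so no step beyond the scatter is expected in this assay, and the compound should remain weak. The expected step is a number no higher from compound 2 to compound 3 (the limit leaves the size open). For compound 3 the estimated value is 30000 nM, with an expected range of 10000 nM to 60000 nM.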

Compound 3, half-maximal inhibitory concentration: 3000 nM
Beside the measured number, compound 3's estimate is 10-fold (1.00 log units) above it, and the stated range ends above it.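

In this assay, the aromatic carbon para to a large group proves to be a position that moves the read-out, with fluoro in place of methoxy giving an at least 10-fold lower number from compound 2 to compound 3 (1.00 log units; beyond the scatter); the earlier step concerned only the saturated chain and could not show this. Compound 2 carries a limit, not a number, so the true size of this step stays unset and only its direction and minimum are fixed: the limit of > 30000 nM in this assay, at which 1 of the 3 values shown sits. With the phenyl retained, the series can therefore still return a measurable value once the 4-methoxyphenyl becomes 4-fluorophenyl.

Going by these compounds, whether the same swap gives a comparable step with the butyl chain of compound 1 remains open. Also open, on these data alone, is how a chloro, a hydroxyl or a dimethylamino group would read at this same position.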